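The source may hold more compounds than are shown below. What is called first, only, known or untested is meant among the compounds shown, and "the series" means these compounds.

Compound 1 `COc1cc(N(CC2CC2)c2ccc(F)c3ccccc23)cnc1C(=O)[C@H]1C[C@@H]1C(=O)O` was examined in an ADME assay on cells (Hepatocyte, Homo sapiens) for metabolic stability, read by LC-MS, with a stated time of 60 min, tested at 1 uM (on this read-out higher numbers stand for fast clearance and lower numbers for slow clearance), where compound 1 gives 5.4 uL/min. Compound 2 `COc1cc(N(CC(C)C)c2ccc(F)c3ccccc23)cnc1C(=O)[C@H]1C[C@@H]1C(=O)O` carries one change against compound 1, (isopropyl in place of cyclopropyl on a saturated chain carbon bound to a nitrogen on an aromatic ring), and in this assay compound 2 gives 56 uL/min. That change made a 10-fold higher number from compound 1 to compound 2 (1.02 log units; beyond the scatter). Compound 3 `COc1cc(N(CC2CC2)c2cc(Cl)c(F)cc2F)cnc1C(=O)[C@H]1C[C@@H]1C(=O)O` rests on a different core; how its core differs from that of compound 1 is not broken down here. In this assay compound 3 gives only a limit of the assay, < 1.5 uL/min. That is the limit of < 1.5 uL/min in this assay, at which 1 of the 3 values shown sits. Compound 4 `COc1cc(N(CC(C)C)c2cc(Cl)c(F)cc2F)cnc1C(=O)[C@H]1C[C@@H]1C(=O)O` has not yet been measured in this assay; it stands to compound 3 as compound 2 stands to compound 1, through the same change, (isopropyl in place of cyclopropyl on a saturated chain carbon bound to a nitrogen on an aromatic ring). Since the measured step of that change was a 10-fold higher number from compound 1 to compound 2 (1.02 log units; beyond the scatter), the same change is expected to make an at least 4.0-fold higher number from compound 3 to compound 4 (0.60 log units; beyond the scatter). Because compound 3 sits at the limit of < 1.5 uL/min in this assay, at which 1 of the 3 values shown sits, the starting point of that step is not a number, and the expectation for compound 4 is the less certain for it. Compound 4 in this assay is therefore estimated at 6 uL/min, with a range from 1.5 uL/min to 20 uL/min.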

Compound 4, intrinsic clearance in a liver preparation (reported as CLH), per the amount of preparation that the assay uses: 4.9 uL/min
Compound 4: middle estimate off by 1.2-fold (0.09 log units), on the high side, within the range that was stated.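

In this assay, isobutyl in place of cyclopropylmethyl again gave a higher number, with an at least 3.2-fold higher number from compound 3 to compound 4 (0.51 log units; beyond the scatter), so the direction of the change held on both the core of compound 1 and the core of compound 3. Compound 3 gives < 1.5 uL/min, which is a limit of the assay and not a number. With only two cores shown, this makes no rule for the whole series, and it does not settle whether the size of the step carried over: the same change on two cores in this assay, a 10-fold higher number (1.02 log units; beyond the scatter) from compound 1 to compound 2 and an at least 3.2-fold higher number (0.51 log units; beyond the scatter) from compound 3 to compound 4; the limit leaves it open whether they differ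

The compounds shown leave open how other groups would compare with cyclopropyl and isopropyl on a saturated chain carbon bound to a nitrogen on an aromatic ring, for instance a longer chain such as n-butyl or a chain ending in an amine. They also leave open whether the same step would appear on a third core, or with an ester in place of the carboxylic acid.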